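The source may report more compounds than this note shows. Statements on the series, on what has been measured and on what is new or still open speak of the compounds shown alone.

Measured compounds:
- compound 1, `CN(C)S(=O)(=O)c1ccc(NC(=S)N2CCC(C(O)(c3ccccc3)c3ccsc3)CC2)cc1`, in a functional assay for antagonist activity at Neuropeptide Y receptor type 2 (Homo sapiens) (on this read-out higher numbers stand for weaker inhibition and lower numbers for stronger inhibition), compound 1 gives 248 nM
- compound 2, `COc1ccc(OC(=O)N2CCC(C(O)(c3ccccc3)c3ccccc3)CC2)cc1`, compound 2 gives 2680 nM
- compound 3, `CCOc1ccc(OC(=O)N2CCC(C(O)(c3ccccc3)c3ccccc3)CC2)cc1`, compound 3 gives 1580 nM

Compound 3 stands second highest of the three numbers; its nearest neighbour is compound 2, and the step of a 1.7-fold lower number from compound 2 to compound 3 (0.23 log units; within the scatter) lies within the scatter. Compound 1 sits furthest off, with a number well below that of compound 3, but compound 1 differs from compound 3 in several places at once, so only its value can be read, not a single step.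

Compound 4, `O=C(Oc1ccc(S(=O)(=O)N2CCCC2)cc1)N1CCC(C(O)(c2ccccc2)c2ccccc2)CC1`, is the next member. Its change from compound 3 is (pyrrolidin-1-yl)sulfonyl in place of ethoxy on an aromatic carbon. Within the data shown here, no measured step carries this change: the one step known, from compound 2 to compound 3, concerns only the size of the alkoxy chain and was within the scatter. Among the measured compounds shown here, the only hint is that compound 1, the sole member bearing a sulfonyl group of this kind, gives 248 nM, the lowest number here. Compound 4 is therefore expected to move toward a lower number, by a 2.6-fold lower number from compound 3 to compound 4 (0.42 log units; beyond the scatter), with wide uncertainty. The estimate for compound 4 is 600 nM, in the range 150 nM to 2500 nM.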

Compound 4, half-maximal inhibitory concentration: 49 nM
The estimate for compound 4 lay 12-fold (1.09 log units) above the measured number; the whole stated range lies above it.
By their numbers in this assay, from the lowest: compound 4; then compound 1; then compounds 3 and 2 (each within the scatter of the next).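

In this assay this aromatic carbon, para to a large group, proves far more responsive than the alkoxy pair suggested: (pyrrolidin-1-yl)sulfonyl in place of ethoxy gives a 32-fold lower number from compound 3 to compound 4 (1.51 log units; beyond the scatter) and in place of methoxy gives a 55-fold lower number from compound 2 to compound 4 (1.74 log units; beyond the scatter) while the rest of the molecule stays the same. Among these compounds, the only earlier change at this carbon, methoxy to ethoxy, stayed within the scatter, so the large steps belong to the exchange of alkoxy for this sulfonyl group, not to a small extension of the chain. No measurement available here bears on the reason for this large step.

Still open, from the compounds shown here alone, is whether the sulfonyl or the pyrrolidine ring carries the step. Methylsulfonyl, morpholin-4-ylsulfonyl or an unsubstituted sulfonamide on the same aromatic carbon would address that question.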